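The source may hold more compounds than are shown below. What is called first, only, known or untested is meant among the compounds shown, and "the series" means these compounds.

In an assay on mitochondria from L6 cells (Rattus norvegicus) for activation, with a stated time of 90 min (a lower number here means that less compound is needed, a higher number that more compound is needed for the effect), three compounds sharing one core have been measured. Compound 1 `Fc1cc(F)cc(Nc2nc3nonc3nc2Nc2cc(F)cc(F)c2)c1` gives only a limit of the assay, < 1000 nM. Compound 2 `FC(F)(F)Oc1cccc(Nc2nc3nonc3nc2Nc2cccc(OC(F)(F)F)c2)c1` gives 1100 nM. Compound 3 `Fc1ccccc1Nc1nc2nonc2nc1NCCC(F)(F)F` also gives only a limit of the assay, > 100000 nM. Compound 3 therefore stands not at a number but at a boundary, the line (the limit of > 100000 nM in this assay, at which 1 of the 3 values shown sits), and nothing closer is known of it. Compound 4 `Fc1ccc(Nc2nc3nonc3nc2Nc2ccccc2F)c(F)c1` differs from compound 3 in one place: 2,4-difluorophenyl in place of 3,3,3-trifluoropropyl on a nitrogen on an aromatic ring. Within the data shown here, no step between measured compounds has been recorded, so the expectation rests on compounds 1 and 2, which each carry two aromatic rings where compound 4 gains its second one. A large step toward less compound needed is expected, an at least 50-fold lower number from compound 3 to compound 4 (1.69 log units; beyond the scatter). Compound 4 is expected to give about 2000 nM in this assay, in a range from 300 nM to 20000 nM.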

Compound 4, half-maximal effective concentration: 300 nM
Compound 4: middle estimate off by 6.7-fold (0.82 log units), on the high side, within the range that was stated.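

Putting 2,4-difluorophenyl in place of 3,3,3-trifluoropropyl on this nitrogen gives the only single-place comparison shown in this assay, with an at least 330-fold lower number from compound 3 to compound 4 (2.52 log units; beyond the scatter). That step is only a minimum, because compound 3 sits at a limit of the assay: the limit of > 100000 nM in this assay, at which 1 of the 4 values shown sits.

It shows that the group at this one place can, by itself, change the result by a large amount, which compound 1 and compound 2 could not show. Still open, on these data alone, is whether the aromatic ring or its fluorine atoms matter here: plain phenyl, cyclohexyl or a longer chain on this nitrogen would help separate the two.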